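Swapping Triazole for Carboxylic Acid: Expected Kinetic Solubility

This account rests on a few compounds, and the source may have more. Where it says the series, first, only, none or still open, it means among the compounds named here.

Compound 1 `COc1ccc(-c2cc(-c3ccc(S(N)(=O)=O)cc3)cnc2N)cn1` gives 12.5 ug/mL in a physicochemical assay for solubility, read by nephelometry, in phosphate buffer, measured as kinetic solubility, at pH 6.5; on this read-out lower numbers stand for lower solubility and higher numbers for higher solubility.
Compound 2 `COc1ccc(-c2cc(-c3ccc(S(=O)(=O)NC4CC4)cc3)cnc2N)cn1` gives 6.3 ug/mL in this assay.
Compound 3 `COc1ccc(-c2cc(-c3ccc(-n4cncn4)cc3)cnc2N)cn1` gives 6.3 ug/mL in this assay.

Compound 3 stands level with compound 2 at the digits shown, the two together the lowest of the three numbers, and the only other step that reaches it is a 2.0-fold lower number from compound 1 to compound 3 (0.30 log units; within the scatter), within the scatter. Compound 4 `COc1ccc(-c2cc(-c3ccc(C(=O)O)cc3)cnc2N)cn1` differs from compound 3 in one place: carboxy in place of 1H-1,2,4-triazol-1-yl on an aromatic carbon. The measured steps that touch this same aromatic carbon are a 2.0-fold lower number from compound 1 to compound 3 (0.30 log units; within the scatter) and no change at the digits printed from compound 2 to compound 3 (within the scatter), both within the scatter, and neither brings in a carboxy, so they set no firm direction. The step of a 4.0-fold higher number from compound 3 to compound 4 (0.60 log units; beyond the scatter) is therefore an estimate carrying a wide range. Compound 4 is expected to give 25 ug/mL, somewhere between 6 ug/mL and 100 ug/mL, in this assay.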

Compound 4, solubility: 6.3 ug/mL
The estimate for compound 4 lay 4.0-fold (0.60 log units) above the measured number; the range from low to high includes it.
By their numbers in this assay, from the lowest: compounds 2, 3, 4 and 1 (each within the scatter of the next).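

With carboxy at this aromatic carbon, this assay shows no change at the digits printed from compound 3 to compound 4 (within the scatter) and also no change at the digits printed from compound 2 to compound 4 (within the scatter) while the comparison with the unsubstituted sulfonamide shows a 2.0-fold lower number from compound 1 to compound 4 (0.30 log units; within the scatter) at the same place. Across the four compounds shown, sulfamoyl, cyclopropylsulfamoyl, 1H-1,2,4-triazol-1-yl and carboxy all give numbers within the scatter of one another, so this change adds a quite different group without a readable shift. No evidence is available that bears on this result.

Going by these compounds, whether an amine or a longer chain at this carbon would give a step beyond the scatter remains open.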